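Two chloro positions on a shared enone core, compared

This account rests on a few compounds, and the source may have more. Where it says the series, first, only, none or still open, it means among the compounds named here.

Four compounds built on one closely related framework are compared in a functional assay on SW-620 cells (Homo sapiens) for cytotoxicity, read by MTT assay, with a stated time of 72 h; a higher number here means a weaker inhibitor, a lower number a stronger inhibitor. Compound 1, `COc1cccc(/C=C2\CCC/C(=C\c3ccccc3Cl)C2=O)c1OC`, gives 10300 nM. Compound 2, `COc1cccc(/C=C2\CCC/C(=C\c3cccc(Cl)c3)C2=O)c1OC`, gives 9100 nM. Compound 3, `COc1ccc(/C=C2\CCC/C(=C\c3ccccc3Cl)C2=O)cc1OC`, gives 7100 nM, the lowest number among the three measured, though its gaps to compound 1 and compound 2 both lie within the usual scatter, so no ordering is claimed among them. Compound 4, `COc1ccc(/C=C2\CCC/C(=C\c3cccc(Cl)c3)C2=O)cc1OC`, has not yet been measured.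

Between compound 1 and compound 2 the change is 3-chlorophenyl in place of 2-chlorophenyl on a double-bonded chain carbon bound to a double-bonded ring carbon, and it made the step of a 1.1-fold lower number from compound 1 to compound 2 (0.05 log units; within the scatter). The very same change, (3-chlorophenyl in place of 2-chlorophenyl on a double-bonded chain carbon bound to a double-bonded ring carbon), separates compound 3 from compound 4. The difference between the core of compound 1 and the core of compound 3 is not broken down here.

Going by the values given here, since the only measured instance of this change moved the number hardly at all, the step from compound 3 to compound 4 in this assay is expected to be similarly small, estimated as a 1.1-fold lower number from compound 3 to compound 4 (0.04 log units; within the scatter). Compound 4 is therefore estimated at 6500 nM, likely between 3500 nM and 12000 nM.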

Compound 4, half-maximal inhibitory concentration: 5100 nM
The estimate for compound 4 lay 1.3-fold (0.11 log units) above the measured number; the measured number falls inside the stated range.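

On the second core, 3-chlorophenyl in place of 2-chlorophenyl in this assay gave a 1.4-fold lower number from compound 3 to compound 4 (0.14 log units; within the scatter). Set beside the earlier step, the same change looks alike on the two cores: the same change on two cores in this assay, a 1.1-fold lower number (0.05 log units; within the scatter) from compound 1 to compound 2 and a 1.4-fold lower number (0.14 log units; within the scatter) from compound 3 to compound 4, 1.2-fold (0.09 log units) apart, within the scatter of two such steps. So in these two pairs the change carried from one core to the other without a visible shift, but both steps are small enough to be lost in the ordinary noise of the measurement, which means the agreement shows only that the swap does little here, not that the chlorine position has a reliable effect or that other cores would respond the same way.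

The compounds shown leave open whether a different group in place of the chlorine on that phenyl ring, such as an amine or a carboxylic acid, would move the number beyond the scatter. They also leave unsettled what the difference between the two cores itself contributes.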